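Amino-pyridyl to tolyl to acetanilide on the shared core

The source may hold more compounds than are shown below. What is called first, only, known or untested is meant among the compounds shown, and "the series" means these compounds.

Compound 2 `CCc1nc(-c2cnc3ccc(-c4ccc(C)cc4)cc3c2)no1` is measured in a functional assay on RD cells (Homo sapiens) for inhibition, read by luminescence and ATP content, with a stated time of 72 h (on this read-out lower numbers stand for higher toxicity in this test and higher numbers for lower toxicity in this test), only as a limit: compound 2 gives > 7400 nM. The other measured member, compound 1 `CCc1nc(-c2cnc3ccc(-c4ccc(N)nc4)cc3c2)no1`, likewise sits at a limit; in this assay compound 1 gives > 66700 nM. For the measured compounds named here, the one measured step, a step that the two limits leave unreadable from compound 1 to compound 2, is unreadable because both ends are limits, as the limit of > 66700 nM in this assay, at which 1 of the 2 values shown sits, and the limit of > 7400 nM in this assay, at which 1 of the 2 values shown sits, show. Compound 3 `CCc1nc(-c2cnc3ccc(-c4ccc(NC(C)=O)cc4)cc3c2)no1` is not yet measured; it differs from compound 2 by acetamido in place of methyl on an aromatic carbon. Going by the values given here, no measured step bears directly on this change, and the single step that exists has no readable size. With both measured compounds sitting at limits in this assay, the expectation for compound 3 is no toxicity beyond the scatter, most likely again a limit rather than a number. The step expected here is a step that the limit leaves unreadable from compound 2 to compound 3, in no direction that can be called beyond the scatter. Compound 3 is estimated at 30000 nM, with a range from 7000 nM to 100000 nM; a reported limit rather than a value is considered the more likely outcome.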

Compound 3, half-maximal cytotoxic concentration: > 7400 nM
Compound 3 was reported as a limit; the forecaster's own chance of this, stated with the estimate: 75%; the middle value does not contradict the limit.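

In this assay compound 3 gives > 7400 nM, which is a limit. For the compounds shown here, compound 2 also stands at a limit there, so no step between compound 2 and compound 3 can be read. The compounds shown leave open where the half-maximal cytotoxic concentration of compound 1, compound 2 or compound 3 actually lies, and whether acetamido and methyl differ at all.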